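A few compounds are considered here, and "the series" means these few. Any claim that something is new, unique, unknown or untested is made for them only; others in the source may bear on it.

Of the three compounds measured in a functional assay on MCF7 cells (Homo sapiens) for inhibition, read by MTT assay, with a stated time of 72 h (a lower number here means a stronger inhibitor, a higher number a weaker inhibitor), compound 1 `Cc1cc(Nc2cc(-c3ccccc3)[nH]n2)n2nc(SCc3csc4ccccc34)nc2n1` gives 3470 nM, the second highest of the three numbers. Its nearest neighbour is compound 3 `Cc1cc(Nc2cc(-c3cccs3)[nH]n2)n2nc(SCc3ccc(Br)cc3)nc2n1`, which gives 5370 nM, within the scatter of compound 1; furthest is compound 2 `Cc1cc(Nc2ccn(Cc3nc(C)c4ccccc4n3)n2)n2nc(SCc3ccc(Br)cc3)nc2n1`, which gives 1430 nM, lower by a gap beyond the scatter. Compound 4 `C#CCSc1nc2nc(C)cc(Nc3cc(-c4ccccc4)[nH]n3)n2n1` differs from compound 1 in one place: ethynyl in place of 1-benzothiophen-3-yl on a saturated chain carbon bound to a sulfur. No measured pair mirrors this change, so nothing shown sets its size or direction. Compound 4 is expected to sit modestly higher than compound 1, a step of a 1.7-fold higher number from compound 1 to compound 4 (0.24 log units; within the scatter) that is estimated to be only slightly beyond the scatter. Compound 4 is estimated to give 6000 nM, between 1800 nM and 20000 nM.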

Compound 4, half-maximal inhibitory concentration: 21800 nM
Beside the measured number, compound 4's estimate is 3.6-fold (0.56 log units) below it, outside the stated range (above it).
By their numbers in this assay, from the lowest: compound 2; then compounds 1 and 3 (each within the scatter of the next); then compound 4.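

In this assay, ethynyl in place of 1-benzothiophen-3-yl on a saturated chain carbon bound to a sulfur gives a 6.3-fold higher number from compound 1 to compound 4 (0.80 log units; beyond the scatter) and lies beyond the scatter. Going by these compounds alone, this is the first single-place comparison here, and it shows that the group held at this position changes the reading. No evidence at hand accounts for the step. Going by these compounds, whether the change tracks the loss of 1-benzothiophen-3-yl or the arrival of ethynyl stays open. On these data alone, how a longer chain or a carboxylic acid would read at this place also stays open.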